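The compounds below may be only part of what the source reports. "The series", "measured", "known", "first", "only" and "open" are said of these compounds alone.

Measured so far in a functional assay on PC-3 cells (Homo sapiens) for cytotoxicity, read by MTT assay, with a stated time of 72 h (on this read-out lower numbers stand for stronger inhibition and higher numbers for weaker inhibition), for the two compounds:

compound 1 `COc1cc2ncnc(Nc3ccc(F)c(Cl)c3)c2cc1NC(=O)/C=C/c1ccc(F)cc1Cl` gives 32700 nM
compound 2 `COc1cc2ncnc(Nc3ccc(F)c(Cl)c3)c2cc1NC(=O)/C=C/c1ccc(C#N)cc1` gives "not active" (no number reported)

Compound 2 therefore has no place on the numerical scale of this assay and its result stands only as "not active" (no number reported) with no single number attached. The compound still to be measured is compound 3 `COc1cc(/C=C/C(=O)Nc2cc3c(Nc4ccc(F)c(Cl)c4)ncnc3cc2OC)cc(OC)c1` and it keeps the shared core and the amide-linked double-bonded chain of compound 2. The structural change is 3,5-dimethoxyphenyl in place of 4-cyanophenyl on a double-bonded chain carbon bound to a double-bonded chain carbon and it puts 3,5-dimethoxyphenyl in place of 4-cyanophenyl on a double-bonded chain carbon bound to a double-bonded chain carbon.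

Within the data shown here, no step can be sized from compound 2, as it has no number to start from. A large gain in this assay is not expected, and the result is expected to lie close to that of compound 1 at 32700 nM with no difference beyond the scatter. A second report without a number would also fit this expectation. The estimated value for compound 3 is 28000 nM with an expected range from 9000 nM to 80000 nM in this estimate.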

Compound 3, half-maximal inhibitory concentration: "not active" (no number reported)
Compound 3 has no reported number here; no gap can be computed for the estimate.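

In this assay compound 3 is reported as "not active" with no number, as is compound 2, so no step can be read between them. The compounds shown leave open how the 3,5-dimethoxyphenyl and 4-cyanophenyl groups compare in numbers in this assay on this read-out. No supporting evidence bears on this result.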